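Changing the Chain End of Compound 3

This account rests on a few compounds, and the source may have more. Where it says the series, first, only, none or still open, it means among the compounds named here.

Compound 1 `CN(C[C@H]1Cc2ncccc2CN1)[C@H]1CCCc2cccnc21` carries no side chain at the amine nitrogen of the shared structure, and in an ADME assay for permeability, using PAMPA, with a stated time of 4 h, at pH 7.4 (on this read-out higher numbers stand for higher permeability and lower numbers for lower permeability), compound 1 gives 1300 nm/s. Compound 2 `NC(=O)NC/C=C\CN(C[C@H]1Cc2ncccc2CN1)[C@H]1CCCc2cccnc21` gives 2 nm/s. Compound 3 `CCN(CC)CCCCN(C[C@H]1Cc2ncccc2CN1)[C@H]1CCCc2cccnc21` gives 240 nm/s, the second highest of the three numbers.

Compound 4 `c1cnc2c(c1)CN[C@@H](CN(CCCCN(C1COC1)C1COC1)[C@H]1CCCc3cccnc31)C2` keeps the chain of compound 3 and alters only its end: a group of 9 heavy atoms (6 carbon, 1 nitrogen, 2 oxygen; 2 four-membered non-aromatic rings with 1 hetero atom each) in place of a group of 5 heavy atoms (4 carbon, 1 nitrogen; no ring), on a saturated chain carbon, four bonds along the chain from an amine nitrogen.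

Going by the values given here, three measured steps bear on this change. Adding the chain with the diethylamino end gave a 5.4-fold lower number from compound 1 to compound 3 (0.73 log units; beyond the scatter), a modest step. Adding the chain of compound 2 gave a 650-fold lower number from compound 1 to compound 2 (2.81 log units; beyond the scatter), a large one. Exchanging one chain for the other gave a 120-fold higher number from compound 2 to compound 3 (2.08 log units; beyond the scatter), so the end of the chain can matter greatly here. The entering group is still an amine, like the group it replaces, so the modest 5.4-fold lower number from compound 1 to compound 3 (0.73 log units; beyond the scatter) seems a better guide than the large 650-fold lower number from compound 1 to compound 2 (2.81 log units; beyond the scatter).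

Among the compounds with values here, no measured compound tests this new group directly, so the direction remains uncertain. A modest rise in this assay is expected, and a small drop cannot be excluded. The expected step is a 2.1-fold higher number from compound 3 to compound 4 (0.32 log units; beyond the scatter). For compound 4 the estimated value is 500 nm/s, with an expected range of 100 nm/s to 1800 nm/s.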

Compound 4, apparent permeability: 320 nm/s
Compound 4: the middle estimate sits 1.6-fold (0.19 log units) above what was measured; the range from low to high includes it.
By their numbers in this assay, from the lowest: compound 2; then compounds 3 and 4 (each within the scatter of the next); then compound 1.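

In this assay, placing the group with 2 four-membered non-aromatic rings where diethylamino stood gives a 1.3-fold higher number from compound 3 to compound 4 (0.12 log units; within the scatter), so this exchange cannot be told apart from no change at all. The earlier compounds shown here showed that the end of this chain can matter greatly, as in a 120-fold higher number from compound 2 to compound 3 (2.08 log units; beyond the scatter), but they did not show how much an amine end can be altered without a step beyond the scatter. Compound 4 adds one such case: on a saturated chain carbon, four bonds along the chain from an amine nitrogen, the end grows in heavy atoms and hydrogen-bond acceptors, gains rings and oxygen, and remains an amine, yet its number stays within the scatter of that of compound 3, and nothing available here accounts for this result.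

Going by these compounds, this is a single exchange, so it remains open whether other amine ends, such as a morpholine or a piperidine, would behave the same way. Also open, on these data alone, is whether the same holds on a longer chain, or with an end that is no amine at all, such as a carboxylic acid.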